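Swapping the benzyl substituent of a weak amine oxidase inhibitor

The source may hold more compounds than are shown below. What is called first, only, known or untested is meant among the compounds shown, and "the series" means these compounds.

Measured compounds:
- compound 1, `C#CCNC1CCc2c(NCc3ccccc3)cccc21`: "not determined" (no result reported) in an ADME assay on cells for inhibition of Amine oxidase [flavin-containing] A (Homo sapiens), read by fluorescence and Amplex Red, with stated times of 30 min and 15 min; on this read-out higher numbers stand for weaker inhibition and lower numbers for stronger inhibition
- compound 2, `C#CCNC1CCc2c(NCc3cccc(Br)c3)cccc21`: 94300 nM in this assay

Among the measured compounds shown here, compound 2 is the only compound with a number; compound 1 has no result, so compound 2 stands alone. For the measured compounds named here, its value lies in the weak range of this assay, and there is no measured pair to show how large a change in the benzyl substituent moves the read-out.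

Compound 3, `C#CCNC1CCc2c(NCc3ccc(C)cc3)cccc21`, differs from compound 2 by 4-methylphenyl in place of 3-bromophenyl on a saturated chain carbon bound to a nitrogen on an aromatic ring. With no comparable step shown, the expectation is a step of about a 1.3-fold higher number from compound 2 to compound 3 (0.10 log units; within the scatter), that is, a change not clearly beyond the scatter. Compound 3 is therefore estimated at 120000 nM, with a range from 40000 nM to 350000 nM.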

Compound 3, half-maximal inhibitory concentration: 43100 nM
Beside the measured number, compound 3's estimate is 2.8-fold (0.44 log units) above it, within the range that was stated.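

In this assay the exchange of 3-bromophenyl for 4-methylphenyl on a saturated chain carbon bound to a nitrogen on an aromatic ring gives a 2.2-fold lower number from compound 2 to compound 3 (0.34 log units; beyond the scatter) and so supplies the first measured size of a change at this place. The read-out can therefore move beyond the scatter with this substituent, though the step is modest and rests on a single pair of compounds. Nothing shown bears on the reason for this step.

This exchange alters both the kind of substituent and the name's ring number at once, and the effects of the two remain unseparated. As far as these compounds go, how 4-bromophenyl or 3-methylphenyl would read stays open, as does the effect of a more different group on this ring, such as an amine or a carboxylic acid.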